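Bromoacrylamide Thiazolidinedione Series: Swapping the Benzyl Aryl Group

This account rests on a few compounds, and the source may have more. Where it says the series, first, only, none or still open, it means among the compounds named here.

Measured so far:
compound 1 `C=C(Br)C(=O)Nc1cccc(/C=C2\SC(=O)N(Cc3cccc(Cl)c3)C2=O)c1` gives 2500 nM
compound 2 `Nc1ccc(/C=C2\SC(=O)N(Cc3ccc(F)cc3)C2=O)cc1` gives 186000 nM
compound 3 `Nc1cccc(/C=C2\SC(=O)N(Cc3cccc(Cl)c3)C2=O)c1` gives 250000 nM

All three numbers come from a functional assay on HeLa cells (Homo sapiens) for cytotoxicity, read by cell counting, with a stated time of 4 days; on this read-out higher numbers stand for weaker inhibition and lower numbers for stronger inhibition. Compound 1 stands lowest of the three in this assay; compound 2 and compound 3, each with hydrogen in place of (1-bromoethenyl)carbonyl on a nitrogen on an aromatic ring, sit far above it. Among the measured compounds shown here, the one single-point step measured is a 100-fold higher number from compound 1 to compound 3 (2.00 log units; beyond the scatter).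

Compound 4 `C=C(Br)C(=O)Nc1cccc(/C=C2\SC(=O)N(Cc3ccc(C(F)(F)F)cc3)C2=O)c1` differs from compound 1 in one place: 4-(trifluoromethyl)phenyl in place of 3-chlorophenyl on a saturated chain carbon bound to an amide-type nitrogen in a ring. For the measured compounds named here, no measured step bears on this change; compound 2 and compound 3 differ from each other in two places, so their values show only that both are weak. A step within the scatter is therefore expected, namely a 1.2-fold higher number from compound 1 to compound 4 (0.08 log units; within the scatter). For compound 4 the estimate in this assay is 3000 nM, with a range of 800 nM to 12000 nM.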

Compound 4, half-maximal inhibitory concentration: 820 nM
Compound 4: the middle estimate sits 3.7-fold (0.56 log units) above what was measured, within the range that was stated.
By their numbers in this assay, from the lowest: compound 4; then compound 1; then compounds 2 and 3 (each within the scatter of the next).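

In this assay, among the compounds shown here, the aryl group on a saturated chain carbon bound to an amide-type nitrogen in a ring can be changed without loss: 4-(trifluoromethyl)phenyl in place of 3-chlorophenyl gives a 3.0-fold lower number from compound 1 to compound 4 (0.48 log units; beyond the scatter) and is the first one-place step read at this position. The entering group is the larger one by heavy atoms, and the number still falls. No evidence on the origin of this step is at hand.

Still open, on these data alone, is whether the trifluoromethyl group itself or its place on the ring carries the step. A plain phenyl or a pyridine ring here would test how far the position depends on either aryl substituent.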